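Pyrazolyl swap on the inactive compound 2

The compounds below may be only part of what the source reports. "The series", "measured", "known", "first", "only" and "open" are said of these compounds alone.

Compound 1 `N#Cc1ccc(N2CCc3cc(-c4cnc5ccccc5c4)ccc32)cc1C(F)(F)F` - "not determined" (no result reported)
Compound 2 `CCN(c1ccc(C#N)c(Cl)c1)c1cc(-c2cncnc2)ccc1C` - > 30000 nM (a limit)

In a functional assay on PC-3 cells (Homo sapiens) for antiproliferative activity, read by CCK-8 assay, with a stated time of 6 days (on this read-out lower numbers stand for stronger inhibition and higher numbers for weaker inhibition), compound 2 stands at > 30000 nM as a limit of the assay and not as a number. Compound 1 gives no comparison, its entry being "not determined" (no result reported) with no result reported. Among the compounds with values here, no single number is therefore available so far.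

Compound 3 `CCN(c1ccc(C#N)c(Cl)c1)c1cc(-n2cccn2)ccc1C` has not yet been measured. It carries 1H-pyrazol-1-yl in place of pyrimidin-5-yl on an aromatic carbon and keeps the rest of compound 2 unchanged.

Within the data shown here, no measured step is available to size this swap, so no shift beyond the scatter is expected in this assay from the sole anchor, compound 2 at > 30000 nM as a limit. The expected change is a number no higher from compound 2 to compound 3 (the limit leaves the size open) and no more than that. For compound 3 the estimate is 30000 nM with an expected range of 12000 nM to 60000 nM on this read-out.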

Compound 3, half-maximal inhibitory concentration: 15700 nM
Estimate against measurement, compound 3: 1.9-fold (0.28 log units) above; the measured number falls inside the stated range.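

In this assay, within the data shown here, compound 3 gives 15700 nM, the first single number, so this place, on the aromatic carbon para to a methyl group, can carry a group that gives a value inside the range of the assay. The swap reads as an at least 1.9-fold lower number from compound 2 to compound 3 (0.28 log units; that floor lies within the scatter). Its true size stays open because compound 2 rests on a limit of the assay, not on a number: the limit of > 30000 nM in this assay, at which 1 of the 3 values shown sits.

The compounds shown do not separate the effect of ring size from that of the arrangement of the ring nitrogens, since 1H-pyrazol-1-yl and pyrimidin-5-yl differ in both. From the compounds shown here alone, how the number responds at this place to a non-aromatic group, such as a morpholine, an amine or a carboxylic acid, also stays open.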